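Swapping pyridazin-4-yl for pyridin-3-yl at the amide

The source may hold more compounds than are shown below. What is called first, only, known or untested is meant among the compounds shown, and "the series" means these compounds.

Values in a physicochemical assay for solubility, measured as kinetic solubility (on this read-out lower numbers stand for lower solubility and higher numbers for higher solubility), stand as follows
compound 1 `O=C(Nc1ccnnc1)c1cc(C(F)(F)F)ccc1OCc1ccccc1` gives < 1000 nM, a limit
compound 2 `O=C(Nc1ccnnc1)c1cc(N2C[C@H]3COC[C@H]3C2)ccc1OCc1ccccc1` gives 57000 nM
compound 3 `O=C(Nc1ccnnc1)c1cc(N2CCC(F)CC2)ccc1OCc1ccccc1` gives 20000 nM

Compound 1 yields only a limit and no number (< 1000 nM). Compound 4 `O=C(Nc1cccnc1)c1cc(C(F)(F)F)ccc1OCc1ccccc1` has pyridin-3-yl in place of pyridazin-4-yl on an amide-type nitrogen. Among the compounds with values here, no measured step changes that group. Two large steps replace trifluoromethyl instead (an at least 57-fold higher number from compound 1 to compound 2 (1.75 log units; beyond the scatter) and an at least 20-fold higher number from compound 1 to compound 3 (1.30 log units; beyond the scatter)), and a modest one compares those replacements (a 2.9-fold lower number from compound 2 to compound 3 (0.45 log units; beyond the scatter)). They therefore offer no direct guide, and no change beyond the scatter is expected in this assay. The step expected is a step that the limit leaves unreadable from compound 1 to compound 4. For compound 4 the estimate is 500 nM, with an expected range of 150 nM to 1500 nM.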

Compound 4, solubility: < 1000 nM
Compound 4: no number, only a limit; the forecaster's own chance of this, stated with the estimate: 70%; the middle value lies beyond the limit too.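

In this assay, compound 1 and compound 4 both give only limits, so no step between them can be read: the limit of < 1000 nM in this assay, at which 2 of the 4 values shown sit.

On these data alone, whether pyridin-3-yl in place of pyridazin-4-yl on an amide-type nitrogen changes the number, and in which direction, remains open.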